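The source may report more compounds than this note shows. Statements on the series, on what has been measured and on what is new or still open speak of the compounds shown alone.

Measured in a functional assay on K562 cells (Homo sapiens) for antiproliferative activity, read by CellTiter-Glo, with a stated time of 72 h; a lower number here means that less compound is needed, a higher number that more compound is needed for the effect:
- Compound 1 `CC(C)(C)CCNc1ncnc2c1ncn2[C@@H]1O[C@H](COS(N)(=O)=O)[C@@H](O)[C@H]1O`: 929 nM
- Compound 2 `CCC(C)Nc1ncnc2c1ncn2[C@@H]1O[C@H](COS(N)(=O)=O)[C@@H](O)[C@H]1O`: > 1000 nM (a limit)
- Compound 3 `NS(=O)(=O)OC[C@H]1O[C@@H](n2cnc3c(NCC4CCCO4)ncnc32)[C@H](O)[C@@H]1O`: > 1000 nM (a limit)

Compound 3 gives only a limit, > 1000 nM. This is the limit of > 1000 nM in this assay, at which 2 of the 3 values shown sit.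

The step followed here leads to compound 4 `NS(=O)(=O)OC[C@H]1O[C@@H](n2cnc3c(NCc4cccs4)ncnc32)[C@H](O)[C@@H]1O`, with thiophen-2-yl in place of oxolan-2-yl on a saturated chain carbon bound to a nitrogen on an aromatic ring.

Among the measured compounds shown here, no measured compound carries thiophen-2-yl. The nearest measured change is at the same place: an at least 1.0-fold higher number from compound 1 to compound 3 (0.03 log units; that floor lies within the scatter). The change on the same nitrogen gives an at least 1.0-fold higher number from compound 1 to compound 2 (0.03 log units; that floor lies within the scatter). The third step gives no size: a step that the two limits leave unreadable from compound 2 to compound 3.

None of these shows a step beyond the scatter, so no step beyond the scatter is expected in either direction in this assay. For the measured compounds named here, the only measured number is that of compound 1, 929 nM, and the expectation stays close to it. The expected step is a number no higher from compound 3 to compound 4 (the limit leaves the size open). For compound 4 the estimated value is 1000 nM, with an expected range of 350 nM to 3000 nM.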

Compound 4, half-maximal effective concentration: 114 nM
The estimate for compound 4 lay 8.8-fold (0.94 log units) above the measured number; measured number outside the range, below it.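

In this assay, the group on a saturated chain carbon bound to a nitrogen on an aromatic ring now shows a step beyond the scatter, which none of the earlier readable steps did: thiophen-2-yl in place of oxolan-2-yl gives an at least 8.7-fold lower number from compound 3 to compound 4 (0.94 log units; beyond the scatter). Among the compounds shown here, the same holds against the other two compounds, with an at least 8.7-fold lower number from compound 2 to compound 4 (0.94 log units; beyond the scatter) and an 8.1-fold lower number from compound 1 to compound 4 (0.91 log units; beyond the scatter), and only this last step has a full size. The first two steps are floors, because compound 2 and compound 3 each give only a limit: the limit of > 1000 nM in this assay, at which 2 of the 4 values shown sit.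

The compounds shown do not separate the aromatic ring of thiophen-2-yl from its sulfur; phenyl or furan-2-yl at the same place would do so. Also open, going by these compounds, is how a longer chain carrying thiophen-2-yl would read.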